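Compound 4: 1-methylheptyl in place of acetyl

A few compounds are considered here, and "the series" means these few. Any claim that something is new, unique, unknown or untested is made for them only; others in the source may bear on it.

In an ADME assay on A549 cells (Homo sapiens) for cytotoxicity, read by LDH release, with a stated time of 15 h (on this read-out higher numbers stand for lower toxicity in this test and lower numbers for higher toxicity in this test), compound 1 (`CC1(Nc2ccc(NC(=O)c3cc(Cl)ccc3O)c(Cl)c2)CCCCC1`) gives 86500 nM and compound 2 (`CCCC(C)(C)Nc1ccc(NC(=O)c2cc(Cl)ccc2O)c(Cl)c1`) gives 23700 nM while compound 3 (`CC(=O)Nc1ccc(NC(=O)c2cc(Cl)ccc2O)c(Cl)c1`) has "not determined" (no result reported) as its entry. Compound 3 therefore offers no number to start from. Compound 4 (`CCCCCCC(C)Nc1ccc(NC(=O)c2cc(Cl)ccc2O)c(Cl)c1`) differs from compound 3 by 1-methylheptyl in place of acetyl on a nitrogen on an aromatic ring with 1-methylheptyl in place of acetyl on a nitrogen on an aromatic ring. No size or direction of step from compound 3 can be stated. For the measured compounds named here, the only measured step is a 3.6-fold lower number from compound 1 to compound 2 (0.56 log units; beyond the scatter) on exchanging 1-methylcyclohexyl for 1,1-dimethylbutyl on that nitrogen, a modest change beyond the scatter. It bears only indirectly, since neither compound carries acetyl, but it suggests that alkyl groups on this nitrogen shift this assay by modest steps. Like 1-methylheptyl, the group of compound 2 has no ring, so compound 2 at 23700 nM serves as the nearest anchor. In this assay the expected value for compound 4 is 22000 nM within an estimated range from 7000 nM to 70000 nM as a working figure.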

Compound 4, half-maximal cytotoxic concentration: 18600 nM
Compound 4: middle estimate off by 1.2-fold (0.07 log units), on the high side, and the stated range covers the measured number.
By their numbers in this assay, from the lowest: compounds 4 and 2 (each within the scatter of the next); then compound 1.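

On a nitrogen on an aromatic ring, 1-methylheptyl in place of 1,1-dimethylbutyl gives a 1.3-fold lower number from compound 2 to compound 4 (0.11 log units; within the scatter) in this assay and so no separable change between these two groups without a ring. 1-Methylheptyl in place of 1-methylcyclohexyl gives a 4.7-fold lower number from compound 1 to compound 4 (0.67 log units; beyond the scatter) and repeats the modest separation first seen with compound 2, so among these three compounds the two groups without a ring stand apart from the ring-bearing group of compound 1. No measurement shown gives a reason for this separation.

The change from acetyl to 1-methylheptyl cannot be read, as compound 3 has no number in this assay to compare. On these data alone, whether a free amine or a cyclohexyl group on this nitrogen would fall with compound 2 and compound 4 or with compound 1 remains open.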